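Adding one carbon to a long ester chain

The compounds below may be only part of what the source reports. "The series", "measured", "known", "first", "only" and "open" are said of these compounds alone.

Compound 1, `CCCCCCCCOC(=O)CCC(=O)N1CCN(CCCOc2cc3c(Nc4ccc(F)c(Cl)c4)ncnc3cc2OC)CC1`, carries an octyl ester at the end of its side chain. In a functional assay on A549 cells (Homo sapiens) for cytotoxicity, read by MTT assay, with a stated time of 24 h, tested at 10 uM (on this read-out lower numbers stand for a stronger effect and higher numbers for a weaker effect at the one concentration tested), compound 1 gives 87.3%. Compound 2, `CCCCCCCCCCCCCCCCCCOC(=O)CCC(=O)N1CCN(CCCOc2cc3c(Nc4ccc(F)c(Cl)c4)ncnc3cc2OC)CC1`, has the same core with a far longer octadecyl ester, and in this assay compound 2 gives 94.8%. Among the compounds with values here, the only measured step, a number 7.5 percentage points higher from compound 1 to compound 2 (within the scatter), shows that stretching the chain by a decyl changed the read-out by an amount within the usual scatter. Within the data shown here, of the two numbers so far, compound 2 holds the higher one, but its gap to compound 1 is within the scatter, so the two are not distinguishable.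

Compound 3, `CCCCCCCCCCCCCCCCCCCOC(=O)CCC(=O)N1CCN(CCCOc2cc3c(Nc4ccc(F)c(Cl)c4)ncnc3cc2OC)CC1`, differs from compound 2 by a single change: methyl in place of hydrogen on a saturated chain carbon, ten or more bonds along the chain from an oxygen next to a carbonyl group. This is a far smaller extension of the same chain than the decyl added between compound 1 and compound 2, which itself produced no step beyond the scatter. The expected step is therefore a number 0.8 percentage points lower from compound 2 to compound 3 (within the scatter), essentially none. Compound 3 is thus estimated at 94%, with a likely range from 85% to 100%.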

Compound 3, a percentage reported as activity, at one concentration (the size of the read-out at that concentration, not a potency): 94.5%
Compound 3: the middle estimate sits 0.5 percentage points below what was measured; low and high end bracket the measured number.
By their numbers in this assay, from the lowest: compounds 1, 3 and 2 (each within the scatter of the next).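

A one-carbon change at the far end of the ester chain is now on record: methyl on a saturated chain carbon gives a number 0.3 percentage points lower from compound 2 to compound 3 (within the scatter) in this assay and so does not separate the two compounds. The larger change, undecyl on a saturated chain carbon, eight bonds along the chain from an oxygen next to a carbonyl group, gives a number 7.2 percentage points higher from compound 1 to compound 3 (within the scatter) and so leaves these three esters indistinguishable in this read-out, whether the added piece is small or large. Nothing available here accounts for this flat picture.

All three compounds end in a plain saturated chain, which leaves open whether a much shorter chain such as butyl, or an amine or a carboxylic acid at the end of the chain, would give a clearly different number. A reading at one concentration also gives no potency, so any difference among these three at other concentrations remains open.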